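A few compounds are considered here, and "the series" means these few. Any claim that something is new, unique, unknown or untested is made for them only; others in the source may bear on it.

Compound 1 `COC(=O)c1cc(=O)c2c(OC)cc(OC)cc2n1S(=O)(=O)c1ccc(C)cc1` gives 139000 nM in an ADME assay on BJ cells (Homo sapiens) for antiproliferative activity, with a stated time of 72 h; a lower number here means that less compound is needed, a higher number that more compound is needed for the effect. Compound 2 `COc1ccc(-c2cc(=O)c3c(OC)cc(OC)cc3n2S(=O)(=O)c2cccc([N+](=O)[O-])c2)cc1` reaches only a limit in this assay, > 39600 nM, so its standing can be told as a boundary and not as a number. Of the values shown, (the limit of > 39600 nM in this assay, at which 1 of the 2 values shown sits). Compound 3 `COc1ccc(-c2cc(=O)c3c(OC)cc(OC)cc3n2S(=O)(=O)c2ccc(OC)cc2)cc1` differs from compound 2 by 4-methoxyphenyl in place of 3-nitrophenyl on a sulfonyl sulfur. Among the measured compounds shown here, no measured pair separates this change, so the expected step that the limit leaves unreadable from compound 2 to compound 3 is small, within the usual scatter and in no clear direction. Compound 3 is therefore estimated to give 60000 nM in this assay, with a likely range from 25000 nM to 200000 nM.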

Compound 3, half-maximal effective concentration: > 82700 nM
Compound 3 ended at the assay's limit (the forecaster's own chance of this, stated with the estimate: 60%); at least 1.3-fold (0.13 log units) between middle value and limit.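

Among the compounds shown here, compound 2 and compound 3 both stand at limits in this assay, and no step between them can be read. The compounds shown leave open whether 4-methoxyphenyl in place of 3-nitrophenyl on a sulfonyl sulfur changes the read-out at all.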